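The source may report more compounds than this note shows. Statements on the series, on what has been measured and on what is new or still open speak of the compounds shown alone.

Compound 2 has the structure `CC(C)(C)OC(=O)NCCCCCNC1=Nc2ccccc2C(CC(=O)NCc2ccccc2)N1c1ccccc1`, and its growth inhibition was measured in a functional assay on DU-145 cells (Homo sapiens) for inhibition, read by sulforhodamine B assay, with a stated time of 72 h (a lower number here means a stronger inhibitor of growth, a higher number a weaker inhibitor of growth), where compound 2 gives 4260 nM. Two other compounds were measured alongside it. Compound 1, `CN(C)C1=Nc2ccccc2C(CC(=O)NCc2ccc(N)cc2)N1c1ccccc1`, differs from compound 2 in several places at once, in the amide part and in the group attached to the exocyclic nitrogen of the shared core. In this assay compound 1 reaches only the assay's limit, > 100000 nM, so no number is known for it (the limit of > 100000 nM in this assay, at which 1 of the 3 values shown sits). Compound 3, `COC(=O)CC1c2ccccc2N=C(Nc2ccc(-c3ccccc3)cc2)N1CCCCCN`, carries a methyl ester and has the 4-phenylphenyl group on the exocyclic nitrogen rather than on the ring nitrogen; in this assay compound 3 gives 4090 nM, a number that sits within the usual scatter of the number for compound 2, so the two cannot be told apart.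

Compound 4, `CC(C)(C)OC(=O)NCCCCCNC1=Nc2ccccc2C(CC(=O)NCc2ccccc2)N1c1ccc(-c2ccccc2)cc1`, has not yet been measured. It differs from compound 2 in one place: phenyl in place of hydrogen on an aromatic carbon, that is, phenyl in place of hydrogen on the ring attached to the ring nitrogen, para to a large group, so that phenyl becomes 4-phenylphenyl. Among the measured compounds shown here, no measured pair shows this exact change, and compound 3 places its 4-phenylphenyl elsewhere, so it cannot serve as a guide. The expected step from compound 2 to compound 4 in this assay is therefore small, a 1.2-fold lower number from compound 2 to compound 4 (0.09 log units; within the scatter), not clearly beyond the scatter in either direction. For compound 4 the estimated value in this assay is 3500 nM, with a range from 800 nM to 15000 nM.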

Compound 4, concentration for 50% growth inhibition: 1640 nM
Estimate against measurement, compound 4: 2.1-fold (0.33 log units) above, within the range that was stated.
By their numbers in this assay, from the lowest: compound 4; then compounds 3 and 2 (each within the scatter of the next). At a limit, above all of these: compound 1.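

In this assay, replacing hydrogen with phenyl on an aromatic carbon, para to a large group, turns phenyl into 4-phenylphenyl and gives a 2.6-fold lower number from compound 2 to compound 4 (0.41 log units; beyond the scatter), a modest step that lies beyond the scatter. Among the compounds shown here, the earlier compounds offered no pair differing in only one place, so this is the first direct reading of a single change. It shows that this position tolerates an added aromatic ring of 6 heavy atoms, and that growth inhibition in these cells improves rather than being lost. Nothing measured here accounts for the size or direction of this step.

A single substituent at a single position cannot show whether the gain is specific to phenyl, or whether a smaller group such as methoxy, or a carboxylic acid, would give a similar, larger or smaller step at the same place. On these data alone, it also remains open whether phenyl would have the same effect with a different amide part or a different chain on the exocyclic nitrogen of the shared core.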